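The source may hold more compounds than are shown below. What is called first, only, known or untested is meant among the compounds shown, and "the series" means these compounds.

Measured compounds:
- compound 1, `Cc1ccc2nc(/N=C3\C(=O)N(CN(c4ccccc4)c4ccccc4)c4cccc(Br)c43)sc2c1` — 30200 nM
- compound 2, `O=C1C(=O)N(CN2CCCCC2)c2cccc(Br)c21` — 31500 nM
- compound 3, `O=C1C(=O)N(CN2CCCCC2)c2cccc(Cl)c21` — 51200 nM

All three values come from a functional assay on MCF7 cells (Homo sapiens) for cytotoxicity, read by sulforhodamine B assay, with a stated time of 48 h; a higher number here means a weaker inhibitor of growth, a lower number a stronger inhibitor of growth. The three numbers lie close together: compound 1 and compound 2 are within the scatter of each other, and compound 3 is within the scatter of both, so no ordering among them is claimed.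

Compound 2 and compound 3 differ in one place, (chloro in place of bromo on an aromatic carbon), and the step is a 1.6-fold higher number from compound 2 to compound 3 (0.21 log units; within the scatter). The difference between the core of compound 1 and the core of compound 2 is not broken down here; they differ in more than one place or by a large part of the molecule, and only their two values can be compared.

The unmeasured compound 4, `Cc1ccc2nc(/N=C3\C(=O)N(CN(c4ccccc4)c4ccccc4)c4cccc(Cl)c43)sc2c1`, differs from compound 1 by chloro in place of bromo on an aromatic carbon. Going by the values given here, this is the same change as that from compound 2 to compound 3, and the description of its place is the same word for word, so the earlier step is the only direct guide. Since the step from compound 2 to compound 3 was a 1.6-fold higher number from compound 2 to compound 3 (0.21 log units; within the scatter), a step of similar size, a 1.5-fold higher number from compound 1 to compound 4 (0.17 log units; within the scatter), is expected from compound 1 to compound 4, with the caveat that the measured step itself sits within the scatter. In this assay compound 4 is thus estimated at 45000 nM, expected to fall between 20000 nM and 100000 nM.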

Compound 4, concentration for 50% growth inhibition: 24300 nM
For compound 4 the middle estimate is 1.9-fold (0.27 log units) above the measured one; low and high end bracket the measured number.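

In this assay, chloro in place of bromo on an aromatic carbon gives a 1.2-fold lower number from compound 1 to compound 4 (0.09 log units; within the scatter) and so stays within the scatter on the core of compound 1, as it did on the core of compound 2. The two steps point in opposite directions as printed, but neither is large enough for that direction to be read, so the pair shows no dependable gain or loss that could be carried from one core to another, and it does not prove that the two cores respond alike beyond these two pairs. What can be said is limited to this: exchanging these two halogens left the number within the scatter on both cores, and the steps do not separate from each other: the same change on two cores in this assay, a 1.6-fold higher number (0.21 log units; within the scatter) from compound 2 to compound 3 and a 1.2-fold lower number (0.09 log units; within the scatter) from compound 1 to compound 4, 2.0-fold (0.31 log units) apart, within the scatter of two such steps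

The compounds shown leave open whether a group less like bromo and chloro on that aromatic carbon, such as fluoro, methoxy or a nitrile, would produce a step beyond the scatter on either core. They also leave open how far the number would move with an amine or a carboxylic acid in place of the groups carried on the ring nitrogen of these cores.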